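The source may hold more compounds than are shown below. What is called first, only, known or untested is meant among the compounds shown, and "the series" means these compounds.

Measured compounds:
- compound 1, `COc1cc(OC)c(/C=C/S(=O)(=O)Cc2ccc(OC)c(OC)c2OC)c(OC)c1`: 15000 nM
- compound 2, `COc1ccc(CS(=O)(=O)/C=C/c2ccc(F)cc2)cc1`: 2000 nM

Both compounds were tested in a functional assay on DLD-1 cells (Homo sapiens) for antiproliferative activity, read by trypan blue exclusion; on this read-out higher numbers stand for weaker inhibition and lower numbers for stronger inhibition. Compound 2 gives the lower of the two numbers, and compound 1 sits a good way above it, beyond the usual scatter, so compound 2 is the stronger inhibitor of the two. Compound 3, `COc1ccc(CS(=O)(=O)/C=C/c2ccc(N)cc2)cc1`, has not yet been measured in this assay. It differs from compound 2 in one place: amino in place of fluoro on an aromatic carbon. For the measured compounds named here, no pair of measured compounds shows a change of this kind, so the data give no direct measure of its effect. A moderate step toward stronger inhibition is expected, of about the size given by a 2.9-fold lower number from compound 2 to compound 3 (0.46 log units; beyond the scatter), although a result within the scatter of compound 2 would not be surprising. Compound 3 is therefore estimated at 700 nM, with a likely range from 150 nM to 3000 nM.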

Compound 3, half-maximal inhibitory concentration: > 20000 nM
Compound 3 was reported as a limit (the forecaster's own chance of this, stated with the estimate: 5%); at least 28-fold (1.45 log units) between middle value and limit.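

This position, an aromatic carbon para to a large group, proves sensitive: in this assay, amino in place of fluoro gives an at least 10-fold higher number from compound 2 to compound 3 (1.00 log units; beyond the scatter). For the compounds shown here, this is the first change at a single place, and its direction is toward weaker inhibition. Compound 3 has no exact value, only a limit of the assay: the limit of > 20000 nM in this assay, at which 1 of the 3 values shown sits.

Going by these compounds, the true size of the step therefore stays unknown, and the two compounds cannot show whether the loss of fluoro or the arrival of amino matters more. Other groups on the same carbon, such as a plain hydrogen, chloro, hydroxyl or an acetamide, would leave open how narrow the tolerance here is and whether any replacement for fluoro keeps the inhibition of compound 2.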